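Adding a Methoxy Group to the Benzyl Ring of Compound 3

The source may hold more compounds than are shown below. What is called first, only, known or untested is meant among the compounds shown, and "the series" means these compounds.

Measured in a functional assay on OVCAR-3 cells (Homo sapiens) for antiproliferative activity, read by WST assay, with a stated time of 72 h; on this read-out lower numbers stand for stronger inhibition and higher numbers for weaker inhibition:
compound 1 `CCCCCCCCCCCCCCCCCC/N=c1\nc(N)c2ncn(Cc3ccccc3)c2c(N)n1` gives 4950 nM
compound 2 `CCCCCCCCCC/N=c1\nc(N)c2ncn(Cc3ccccc3)c2c(N)n1` gives 3950 nM
compound 3 `CCCCCCCC/N=c1\nc(N)c2ncn(Cc3ccccc3)c2c(N)n1` gives 4980 nM

The three measured compounds share one core and differ only in the length of the saturated chain on the double-bonded nitrogen. Compound 3 has the highest of the three numbers in this assay, yet the steps leading to it, a 1.0-fold higher number from compound 1 to compound 3 (0.00 log units; within the scatter) and a 1.3-fold higher number from compound 2 to compound 3 (0.10 log units; within the scatter), both lie within the scatter, as does a 1.3-fold lower number from compound 1 to compound 2 (0.10 log units; within the scatter); chain length, on this evidence, does not move the read-out.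

Compound 4 `CCCCCCCC/N=c1\nc(N)c2ncn(Cc3ccc(OC)cc3)c2c(N)n1` differs from compound 3 in another place: methoxy in place of hydrogen on an aromatic carbon. No measured step touches this ring, so nothing shown bears directly on the change. With no guidance in either direction, compound 4 is expected to stay close to compound 3, a step of a 1.1-fold lower number from compound 3 to compound 4 (0.04 log units; within the scatter). The estimate for compound 4 is therefore 4500 nM, within a range of 1500 nM to 13000 nM.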

Compound 4, half-maximal inhibitory concentration: 3750 nM
Compound 4: the middle estimate sits 1.2-fold (0.08 log units) above what was measured; the range from low to high includes it.
By their numbers in this assay, from the lowest: compounds 4, 2, 1 and 3 (each within the scatter of the next).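

Benzyl to 4-methoxybenzyl is the first change shown on the ring rather than the chain, and in this assay it gives a 1.3-fold lower number from compound 3 to compound 4 (0.12 log units; within the scatter) and so moves the read-out no further than the chain changes did. Methoxy in place of hydrogen on this aromatic carbon, para to a large group, is therefore accepted in this assay without a shift beyond the scatter. No evidence is available that bears on this result. As far as these compounds go, whether an amine or a carboxylic acid at this place would read differently stays open, as does whether the same ring change would read alike on the longer chain of compound 2.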